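Furan in Place of the Hydroxymethoxybenzyl Group

The source may report more compounds than this note shows. Statements on the series, on what has been measured and on what is new or still open speak of the compounds shown alone.

Measured so far:
compound 1 `COc1ccc(Oc2ccc3c(NCCCNCc4cccc(OC)c4O)ccnc3c2)cc1` gives 317 10^-6 cm/s
compound 2 `COc1cccc(CNCCCNc2ccnc3cc(-c4cc(C(F)(F)F)cc(C(F)(F)F)c4)ccc23)c1O` gives 237 10^-6 cm/s
compound 3 `c1coc(CNCCCNc2ccnc3cc(C4CCCCC4)ccc23)c1` gives 23 10^-6 cm/s

Of the compounds shown here, three sharing the same core have been measured in an ADME assay for permeability, using PAMPA, with a stated time of 30 min, at pH 7.4; a higher number here means that the compound crosses the layer faster, a lower number that the compound crosses the layer more slowly. Compound 2 stands second highest of the three numbers. Its nearest neighbour is compound 1, whose value lies within the scatter of that of compound 2, so no order between them can be claimed. Its furthest neighbour is compound 3, which lies well beyond the scatter, lower than compound 2.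

Compound 4 `FC(F)(F)c1cc(-c2ccc3c(NCCCNCc4ccco4)ccnc3c2)cc(C(F)(F)F)c1` has not yet been measured. It differs from compound 2 in one place: furan-2-yl in place of 2-hydroxy-3-methoxyphenyl on a saturated chain carbon bound to an amine nitrogen. Compound 3, which also carries the (furan-2-yl)methyl group on its amine nitrogen, differs from compound 2 in a second place as well, so what its value shows cannot be tied to this change alone.

The step from compound 2 to compound 4 in this assay is expected to run downward, a 2.4-fold lower number from compound 2 to compound 4 (0.37 log units; beyond the scatter), likely beyond the scatter but not as far as the value of compound 3. Compound 4 is therefore estimated at 100 10^-6 cm/s, with a range from 35 10^-6 cm/s to 260 10^-6 cm/s.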

Compound 4, apparent permeability in the ADME assay: 237 10^-6 cm/s
Compound 4: the middle estimate sits 2.4-fold (0.37 log units) below what was measured, within the range that was stated.
By their numbers in the ADME assay, from the lowest: compound 3; then compounds 2, 4 and 1 (each within the scatter of the next).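

In the ADME assay, placing furan-2-yl for 2-hydroxy-3-methoxyphenyl on a saturated chain carbon bound to an amine nitrogen gives no change at the digits printed from compound 2 to compound 4 (within the scatter), so at this position the smaller group, with no hydrogen-bond donor, leaves the number in place. In a physicochemical assay for acid dissociation, compound 2 gives 9.47 and compound 4 gives 9.47, so that read-out also stays the same at the digits printed. The (furan-2-yl)methyl group on the amine nitrogen therefore does not by itself go with a number as low as that of compound 3.

No measurement shown offers an explanation for either result. Going by these compounds, whether a thiophen-2-yl or pyridin-2-yl group in this place would give the same number in the ADME assay remains open, as does whether this step would hold with the cyclohexyl group of compound 3.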